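This account rests on a few compounds, and the source may have more. Where it says the series, first, only, none or still open, it means among the compounds named here.

Compound 2 `COc1c(Br)cccc1C(=O)Nc1ccc(Sc2nc3ccccc3s2)cc1` is one of three amides that share a single core and differ only in the group attached to the carbonyl carbon. In an assay on isolated protein for inhibition of thiosulfate sulfurtransferase (Homo sapiens), with a stated time of 60 min, in the absence of a further agent (on this read-out higher numbers stand for weaker inhibition and lower numbers for stronger inhibition), compound 2 gives > 100000 nM, which is a limit of the assay rather than a number. Compound 1 `COc1ccc(Br)cc1C(=O)Nc1ccc(Sc2nc3ccccc3s2)cc1` gives in this assay > 100000 nM, likewise a limit. Compound 3 `O=C(Nc1ccc(Sc2nc3ccccc3s2)cc1)c1ccccc1O` gives in this assay > 100000 nM, again a limit. As far as these compounds go, because of the limit of > 100000 nM in this assay, at which 3 of the 3 values shown sit, none of the steps among the measured compounds can be read: a step that the two limits leave unreadable from compound 1 to compound 2, a step that the two limits leave unreadable from compound 1 to compound 3 and a step that the two limits leave unreadable from compound 2 to compound 3 all stay hidden behind the same limit, so their size and direction are unknown.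

Compound 4 `COc1c(Br)cc(Br)cc1C(=O)Nc1ccc(Sc2nc3ccccc3s2)cc1` is built from compound 2 by a single change: bromo in place of hydrogen on an aromatic carbon, the new bromo sitting meta to a bromo group, meta to a large group and para to a methoxy group. Within the data shown here, no measured step bears on this change, since every step available is unreadable, and the only evidence is that the whole series sits at the limit of > 100000 nM in this assay, at which 3 of the 3 values shown sit. Compound 4 is therefore expected to give 100000 nM in this assay, with a range from 30000 nM to 300000 nM, most probably reported once more as a limit. The expected step is a number no higher from compound 2 to compound 4 (the limit leaves the size open), nothing beyond the scatter.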

Compound 4, half-maximal inhibitory concentration: > 100000 nM
Compound 4: only a limit was reported; the forecaster's own chance of this, stated with the estimate: 85%; the middle value lies on the limit itself.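

In this assay compound 4 gives > 100000 nM, again a limit, so neither its step from compound 2 nor its step from compound 1 can be read: the limit of > 100000 nM in this assay, at which 4 of the 4 values shown sit. The compounds shown leave open how large any of these changes on the shared core is, in which direction it runs, and what actual value any of the four compounds would give.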